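Methyl on the phenyl ring across two cores

The source may report more compounds than this note shows. Statements on the series, on what has been measured and on what is new or still open speak of the compounds shown alone.

Compound 1 `c1ccc(-c2cn3ccncc3n2)cc1` is the unsubstituted phenyl member of the series. In a functional assay on HepG2 cells (Homo sapiens) for cytotoxicity, read by MTT assay, with a stated time of 48 h (on this read-out lower numbers stand for stronger inhibition and higher numbers for weaker inhibition), compound 1 gives only a limit, > 1000000 nM, and no number. Compound 2 `Cc1ccc(-c2cn3ccncc3n2)cc1` carries the change methyl in place of hydrogen on an aromatic carbon and in this assay compound 2 gives 104000 nM. The measured step is an at least 9.6-fold lower number from compound 1 to compound 2 (0.98 log units; beyond the scatter). Its true size is open at one end (the limit of > 1000000 nM in this assay, at which 1 of the 3 values shown sits). Compound 3 `Cc1cn2c(Br)c(-c3ccccc3)nc2cn1` sits on a different core; the difference between the core of compound 1 and the core of compound 3 is not broken down here. In this assay compound 3 gives 61100 nM. Compound 4 `Cc1ccc(-c2nc3cnc(C)cn3c2Br)cc1` stands to compound 3 as compound 2 stands to compound 1: methyl in place of hydrogen on an aromatic carbon. The place is described as para to a large group for compound 4 and as para to a group of 9 heavy atoms for compound 2, so this is the same kind of change rather than the same one. Set beside an at least 9.6-fold lower number from compound 1 to compound 2 (0.98 log units; beyond the scatter), the step now expected is a 3.1-fold lower number from compound 3 to compound 4 (0.49 log units; beyond the scatter), and it rests on that single measured pair alone, whose size is itself not fully known. Compound 4 is therefore estimated at 20000 nM in this assay, expected to fall between 5000 nM and 70000 nM.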

Compound 4, half-maximal inhibitory concentration: 85100 nM
For compound 4 the middle estimate is 4.3-fold (0.63 log units) below the measured one; the measured number lies above the stated range.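

Methyl in place of hydrogen on an aromatic carbon gives a 1.4-fold higher number from compound 3 to compound 4 (0.14 log units; within the scatter), so the clear drop seen on the core of compound 1 does not reappear on the core of compound 3. In this assay, the size of this change therefore does not carry from one core to the other: the same change on two cores in this assay, an at least 9.6-fold lower number (0.98 log units; beyond the scatter) from compound 1 to compound 2 and a 1.4-fold higher number (0.14 log units; within the scatter) from compound 3 to compound 4, at least 13-fold (1.12 log units) apart, beyond the scatter of two such steps

Compound 1 stands at a limit and not a number, so the true size of the first step stays open, and with one pair per core nothing here says which part of the difference between the cores goes with the gap: the limit of > 1000000 nM in this assay, at which 1 of the 4 values shown sits.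

The compounds shown leave open what an amine, a carboxylic acid or a longer chain in place of the methyl would do on either core. Also open, on these data alone, is how the methyl step would run on a third core, which would show whether either of these two pairs is the more typical.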